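A few compounds are considered here, and "the series" means these few. Any claim that something is new, unique, unknown or untested is made for them only; others in the source may bear on it.

Compound 1 `COc1ccc2c(c1)[n+]([O-])nc(NCOC(C)c1ccccc1)[n+]2[O-]` gives 220 nM in a functional assay on KB cells (Homo sapiens) for cytotoxicity, read by MTT assay, with a stated time of 72 h; on this read-out lower numbers stand for stronger inhibition and higher numbers for weaker inhibition. Compound 2 `COCNc1n[n+]([O-])c2ccccc2[n+]1[O-]` gives 1580 nM in this assay. Compound 3 `COc1ccc(COCNc2n[n+]([O-])c3ccccc3[n+]2[O-])cc1` gives 4060 nM in this assay.

Among these three, compound 1 stands at the lowest number with 220 nM; compound 2 is nearest, with 1580 nM, and compound 3 is furthest, with 4060 nM. Compound 2 and compound 3 share a core that differs from that of compound 1, so their values cannot be set directly against compound 1, but the step between them speaks to the ether substituent: a 2.6-fold higher number from compound 2 to compound 3 (0.41 log units; beyond the scatter).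

Compound 4 `CCCCCOCNc1n[n+]([O-])c2cc(OC)ccc2[n+]1[O-]` keeps the core of compound 1 and changes only the ether substituent: pentyl in place of 1-phenylethyl on an oxygen on a saturated carbon. Within the data shown here, the change runs opposite in kind to the one from compound 2 to compound 3, since the aromatic ring leaves rather than enters, yet a five-carbon chain takes its place instead of hydrogen. Among the measured compounds shown here, the one step that bears on it was modest and beyond the scatter, pointing to a lower number on loss of the ring, while the pentyl chain is untested here. A small step, at most modest and more likely downward or within the scatter, is therefore expected in this assay.

Compound 4 is thus estimated at 180 nM in this assay, within 70 nM to 500 nM, which is expected to mean a 1.2-fold lower number from compound 1 to compound 4 (0.09 log units; within the scatter).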

Compound 4, half-maximal inhibitory concentration: 2810 nM
Estimate against measurement, compound 4: 16-fold (1.19 log units) below; the measured number lies above the stated range.
By their numbers in this assay, from the lowest: compound 1; then compounds 2, 4 and 3 (each within the scatter of the next, the first and the last beyond it).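

In this assay the ether substituent on the core of compound 1 proves to be a place where the number can move a long way: the large step on putting pentyl in place of 1-phenylethyl on an oxygen on a saturated carbon is a 13-fold higher number from compound 1 to compound 4 (1.11 log units; beyond the scatter) and lies beyond the scatter. The earlier step, on the other core, was a 2.6-fold higher number from compound 2 to compound 3 (0.41 log units; beyond the scatter) and came with an aromatic ring entering, whereas here the number rises as an aromatic ring leaves, so across these two pairs the presence of a ring in the ether substituent does not by itself set the direction of change. No supporting measurement is available to explain this step.

On these data alone, the step from compound 1 to compound 4 changes the ring, the branching and the chain at once, so which of these carries it stays open. As far as these compounds go, how a benzyl group, a cyclohexyl ring or a longer chain would stand on that same oxygen, and whether pentyl would behave the same way on the other core, also remains open.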